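Swapping the isopropylphenyl of compound 1 for dichlorophenyl

A few compounds are considered here, and "the series" means these few. Any claim that something is new, unique, unknown or untested is made for them only; others in the source may bear on it.

Measured compounds in an in vitro assay on BHK cells for inhibition of Glucagon receptor (Homo sapiens); on this read-out higher numbers stand for weaker inhibition and lower numbers for stronger inhibition:
- compound 1 `CC(C)c1ccc(NC(=O)N(Cc2ccc(C(=O)NCCC(=O)O)cc2)[C@H]2CC[C@H](C(C)(C)C)CC2)cc1` gives 35 nM
- compound 2 `CCN(CC)C(=O)c1ccc(NC(=O)N(Cc2ccc(C(=O)NCCC(=O)O)cc2)[C@H]2CC[C@H](C(C)(C)C)CC2)cc1` gives 2430 nM
- compound 3 `CC(C)(C)[C@H]1CC[C@H](N(Cc2ccc(C(=O)NCCC(=O)O)cc2)C(=O)Nc2ccc(OCC3CC3)cc2C(F)(F)F)CC1` gives 182 nM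

Compound 1 has the lowest number of the three; compound 3 is the nearest to it and compound 2 the furthest. Compound 4 `CC(C)(C)[C@H]1CC[C@H](N(Cc2ccc(C(=O)NCCC(=O)O)cc2)C(=O)Nc2cc(Cl)cc(Cl)c2)CC1` differs from compound 1 by 3,5-dichlorophenyl in place of 4-isopropylphenyl on an amide-type nitrogen. Within the data shown here, no measured step covers this exact exchange. Among the measured compounds shown here, the only step at the same position, a 69-fold higher number from compound 1 to compound 2 (1.84 log units; beyond the scatter), shows that this part of the molecule matters strongly, and compound 3, which carries yet another group there, also gives a higher number than compound 1. Compound 4 is therefore expected to give a somewhat higher number than compound 1, estimated as 110 nM (range 25 nM to 500 nM), a step of a 3.1-fold higher number from compound 1 to compound 4 (0.50 log units; beyond the scatter).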

Compound 4, half-maximal inhibitory concentration: 80 nM
For compound 4 the middle estimate is 1.4-fold (0.14 log units) above the measured one, and the stated range covers the measured number.
By their numbers in this assay, from the lowest: compound 1; then compound 4; then compound 3; then compound 2.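

In this assay the change from 4-isopropylphenyl to 3,5-dichlorophenyl gives a 2.3-fold higher number from compound 1 to compound 4 (0.36 log units; beyond the scatter) and is much smaller than a 69-fold higher number from compound 1 to compound 2 (1.84 log units; beyond the scatter) at the same place. The position therefore accepts a ring without the isopropyl group at only modest cost, although compound 1 still gives the lowest number. Nothing measured here explains this step. Going by these compounds, it remains open how a single chlorine would compare with two, and whether a methoxy group or an amine on this ring would keep the number as low.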